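Series notes: from compound 3 to compound 4

A few compounds are considered here, and "the series" means these few. Any claim that something is new, unique, unknown or untested is made for them only; others in the source may bear on it.

Measured so far:
compound 1 `CCn1c(SCC(=O)Nc2ccc(C(C)=O)cc2)nnc1-c1ccc(OC)c(OC)c1`: 62%
compound 2 `CCn1c(SCC(=O)Nc2ccc(C(C)=O)cc2)nnc1-c1ccc(OC)cc1`: 57%
compound 3 `CCn1c(SCC(=O)Nc2ccc(/C(C)=N/O)cc2)nnc1-c1ccccc1`: 65%

In a functional assay on the whole organism (strain albino) for inhibition, with Rattus norvegicus as the target, read by paw edema, with stated times of 30 min and 3 h, at a dose of 0.28 mmol/kg by the oral route (on this read-out lower numbers stand for less inhibition and higher numbers for more inhibition at the one dose given (going by the name of the read-out)), compound 3 gives 65%, the highest of the three numbers, though its gaps to compound 1 and compound 2 both lie within the scatter. Compound 4 `CCn1c(SCC(=O)Nc2ccc(C(C)=O)cc2)nnc1-c1ccccc1` differs from compound 3 in one place: a group of 3 heavy atoms (2 carbon, 1 oxygen; no ring) in place of a group of 4 heavy atoms (2 carbon, 1 nitrogen, 1 oxygen; no ring), on an aromatic carbon. Going by the values given here, no measured pair shows this exchange. Among the compounds with values here, the only one-place step in hand, a number 5 percentage points lower from compound 1 to compound 2 (within the scatter), concerns a different change and stayed within the scatter; all three measured numbers sit close together. Within the data shown here, with no precedent for the exchange, the step of a number 5 percentage points lower from compound 3 to compound 4 (within the scatter) is expected to stay within the scatter. Compound 4 is therefore estimated at 60%, with a range of 48% to 72%.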

Compound 4, a percentage reported as inhibition, in the whole organism at one dose (the size of the read-out at that dose, not a potency): 56%
Beside the measured number, compound 4's estimate is 4 percentage points above it; measured number inside the range.
By their numbers in this assay, from the lowest: compounds 4, 2, 1 and 3 (each within the scatter of the next).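

On the aromatic carbon para to a large group, acetyl in place of the group of 4 heavy atoms gives a number 9 percentage points lower from compound 3 to compound 4 (within the scatter) in this assay, so the exchange, which takes away the hydrogen-bond donor, does not separate the two compounds at this dose. With acetyl in place, hydrogen in place of methoxy gives a number 1 percentage points lower from compound 2 to compound 4 (within the scatter) and phenyl in place of 3,4-dimethoxyphenyl gives a number 6 percentage points lower from compound 1 to compound 4 (within the scatter), so the methoxy groups do not separate these compounds either. Nothing at hand bears on the reason for these results. Open, from the compounds shown here alone, is whether a carboxylic acid or an amine on the same aromatic carbon would give a step beyond the scatter.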